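The source may report more compounds than this note shows. Statements on the series, on what has been measured and on what is new or still open speak of the compounds shown alone.

Working notes on the series. Three compounds share a saturated bicyclic core and differ in the thiourea or urea linker, the halogen on the core and the chlorophenyl group. Compound 3, `CC1(C)CC(NC(=S)Nc2ccc(Cl)cc2)c2cc(Br)ccc2O1`, carries a thiocarbonyl linker and a 4-chlorophenyl group; in a functional assay on B16-F10 cells (Mus musculus) for inhibition, read by MTT assay, with a stated time of 72 h (on this read-out higher numbers stand for weaker inhibition and lower numbers for stronger inhibition), compound 3 gives 7000 nM. Compound 1, `CC1(C)CC(NC(=S)Nc2cccc(Cl)c2)c2cc(Br)ccc2O1`, keeps the thiocarbonyl linker and the core of compound 3 but carries the 3-chlorophenyl group; in this assay compound 1 gives 7000 nM. The step of no change at the digits printed from compound 3 to compound 1 (within the scatter) covers (3-chlorophenyl in place of 4-chlorophenyl on an amide-type nitrogen).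

Compound 2, `CC1(C)CC(NC(=O)Nc2ccc(Cl)cc2)c2cc(Cl)ccc2O1`, has a carbonyl linker in place of the thiocarbonyl and chlorine in place of bromine on the core; in this assay compound 2 gives 32000 nM, the highest of the three numbers, and its gap to compound 1 and to compound 3 is beyond the scatter. The difference between the core of compound 2 and the core of compound 3 is not broken down here.

Compound 4, `CC1(C)CC(NC(=O)Nc2cccc(Cl)c2)c2cc(Cl)ccc2O1`, is not yet measured. It differs from compound 2 by 3-chlorophenyl in place of 4-chlorophenyl on an amide-type nitrogen. Within the data shown here, the change is of the same kind as the one from compound 3 to compound 1, but the amide-type nitrogen has a carbonyl carbon as its other neighbour in compound 2 and compound 4, whereas in compound 3 and compound 1 it has a thiocarbonyl carbon. The step of no change at the digits printed from compound 2 to compound 4 (within the scatter) is expected to be small, as the earlier step of no change at the digits printed from compound 3 to compound 1 (within the scatter) was. Compound 4 is therefore estimated at 32000 nM in this assay, within 14000 nM to 70000 nM.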

Compound 4, half-maximal inhibitory concentration: 25000 nM
Compound 4: middle estimate off by 1.3-fold (0.11 log units), on the high side; low and high end bracket the measured number.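

The change to 3-chlorophenyl in place of 4-chlorophenyl on an amide-type nitrogen, now read with a carbonyl linker, gives a 1.3-fold lower number from compound 2 to compound 4 (0.11 log units; within the scatter). Set beside the same change with a thiocarbonyl linker, the step carries from one core to the other with no readable difference in this assay: the same change on two cores in this assay, no change at the digits printed (within the scatter) from compound 3 to compound 1 and a 1.3-fold lower number (0.11 log units; within the scatter) from compound 2 to compound 4, 1.3-fold (0.11 log units) apart, within the scatter of two such steps. This rests on two pairs, both within the scatter, so it shows only that exchanging these two chlorophenyl groups leaves the number unchanged within the scatter on these two cores; it does not show that the same would hold on any other core, and it does not separate the contribution of the linker from that of the halogen on the core, since the two pairs differ in both.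

As far as these compounds go, how much of the gap between the carbonyl and thiocarbonyl compounds belongs to the linker and how much to chlorine or bromine on the core stays open, and a carbonyl linker paired with bromine on the core would bear on that. Also open, from the compounds shown here alone, is how the series responds when the chlorine on the phenyl ring gives way to another group, such as a methoxy group, a nitrile or a carboxylic acid.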